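From Acetamide to a Trifluoromethylphenyl Amide

The source may hold more compounds than are shown below. What is called first, only, known or untested is meant among the compounds shown, and "the series" means these compounds.

Three compounds sharing a common core were tested in an assay on isolated protein for inhibition of Rho-associated protein kinase 1 (Homo sapiens), read by scintillation counting, radiometric assay and 33P incorporation, with a stated time of 40 min, in the presence of a further agent that is not named here; a lower number here means a stronger inhibitor, a higher number a weaker inhibitor. Among the measured compounds shown here, compound 1 `CN(C)c1ccc(C(=O)Nc2cccc(NC(=O)COc3ccc4c(c3)OCCO4)c2)cc1` is the first of them. In this assay compound 1 gives > 10000 nM, which is a limit of the assay rather than a number. Compound 2 `Cc1c(OCC(=O)Nc2cccc(NC(=O)c3ccc(N(C)C)cc3)c2)ccc2c(=O)ccoc12` is the second. In this assay compound 2 gives > 10000 nM, again a limit and not a number. Compound 3 `CC(=O)Nc1cccc(NC(=O)COc2ccc3c(=O)ccoc3c2)c1` is the third, and in this assay compound 3 gives 2500 nM. For the measured compounds named here, of the three values shown, compound 3 holds the only number, since the others sit at the limit of > 10000 nM in this assay, at which 2 of the 3 values shown sit.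

Compound 4 `Cc1cc(C(=O)Nc2cccc(NC(=O)COc3ccc4c(=O)ccoc4c3)c2)ccc1C(F)(F)F` has not yet been measured. It differs from compound 3 in one place: a group of 11 heavy atoms (8 carbon, 3 fluorine; one six-membered aromatic ring of carbon only) in place of one carbon atom, on a carbonyl carbon. Going by the values given here, no step between two measured compounds that differ in a single place is available, so the size of such a change cannot be read from a measured pair. Compounds 1 and 2 each carry an aromatic ring on the carbonyl carbon where compound 3 carries the methyl, and neither of them yields a number. On that basis compound 4 is expected to be a somewhat weaker inhibitor than compound 3, with an expected step of a 2.4-fold higher number from compound 3 to compound 4 (0.38 log units; beyond the scatter). The estimate for compound 4 in this assay is 6000 nM, with a range from 2000 nM to 20000 nM.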

Compound 4, half-maximal inhibitory concentration: 460 nM
Compound 4: the middle estimate sits 13-fold (1.12 log units) above what was measured; measured number outside the range, below it.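

In this assay, replacing the methyl on this carbonyl carbon, whose other neighbour is an amide-type nitrogen, with the much larger aromatic group gives a 5.4-fold lower number from compound 3 to compound 4 (0.74 log units; beyond the scatter). Among the compounds shown here, this is the first direct reading at this position, and it shows that a group of 11 heavy atoms carrying a six-membered aromatic ring can stand here while the compound becomes a stronger inhibitor, by a margin beyond the usual scatter. Compounds 1 and 2 also carry an aromatic ring on this carbonyl carbon, but each differs from compound 4 in more than one place, so they cannot be compared with it directly and could not have revealed this step: the limit of > 10000 nM in this assay, at which 2 of the 4 values shown sit.

What remains open is which part of the new group accounts for the change, the ring itself or the trifluoromethyl and methyl groups on it; a plain phenyl ring, a cyclohexyl ring or a lone trifluoromethyl group on the same carbonyl carbon would help separate these parts. This single step also leaves open whether the same exchange would have a similar effect on a different core, such as that of compound 1.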